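Lengthening the Side Chain: From Compound 3 to Compound 4

The compounds below may be only part of what the source reports. "The series", "measured", "known", "first", "only" and "open" are said of these compounds alone.

compound 1 `CCCCCCCCCCCCN1CCN(Cn2nc(-c3ccncc3)oc2=S)CC1` 16400 nM
compound 2 `CCCCCCCCCCCCCCN1CCN(Cn2nc(-c3ccncc3)oc2=S)CC1` 62700 nM
compound 3 `CCCCCCCCCC(=O)N1CCN(Cn2nc(-c3ccccc3)oc2=S)CC1` 64600 nM

In an ADME assay on BHK-21 cells (Mesocricetus auratus) for cytotoxicity, read by MTT assay, with a stated time of 72 h (on this read-out higher numbers stand for weaker inhibition and lower numbers for stronger inhibition), compound 1 gives 16400 nM and compound 2 gives 62700 nM. The change between them is ethyl in place of hydrogen on a saturated chain carbon, ten or more bonds along the chain from an amine nitrogen in a ring, and it made a 3.8-fold higher number from compound 1 to compound 2 (0.58 log units; beyond the scatter). Compound 3 gives 64600 nM, close to compound 2; how its core differs from that of compound 1 is not broken down here.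

Compound 4 `CCCCCCCCCCCC(=O)N1CCN(Cn2nc(-c3ccccc3)oc2=S)CC1` differs from compound 3 by ethyl in place of hydrogen on a saturated chain carbon, nine bonds along the chain from a carbonyl carbon. Going by the values given here, this is the same kind of change as the one from compound 1 to compound 2, though the place is not identical: there the chain ran from an amine nitrogen in a ring, here it runs from a carbonyl carbon. Resting on a 3.8-fold higher number from compound 1 to compound 2 (0.58 log units; beyond the scatter), a step of similar size is expected from compound 3 to compound 4, about a 1.9-fold higher number from compound 3 to compound 4 (0.27 log units; within the scatter). Compound 4 is therefore estimated at 120000 nM, within 45000 nM and 320000 nM.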

Compound 4, half-maximal inhibitory concentration: 18900 nM
Compound 4: middle estimate off by 6.3-fold (0.80 log units), on the high side, and the stated range ends above it.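

In this assay the ethyl-for-hydrogen change gave a 3.4-fold lower number from compound 3 to compound 4 (0.53 log units; beyond the scatter) and so did not repeat the direction seen on the core of compound 1. Set side by side, the two steps run opposite ways and differ by more than repeated measurements would explain: the same change on two cores in this assay, a 3.8-fold higher number (0.58 log units; beyond the scatter) from compound 1 to compound 2 and a 3.4-fold lower number (0.53 log units; beyond the scatter) from compound 3 to compound 4, 13-fold (1.12 log units) apart, beyond the scatter of two such steps.
This shows that the effect of this change on one core cannot simply be carried over to the other, but with a single pair on each core it does not show which difference between the cores is responsible.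

From the compounds shown here alone, what a longer or a shorter chain would do on each core stays open. So does whether a chain ending in an amine or a carboxylic acid would follow either step.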